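A few compounds are considered here, and "the series" means these few. Any claim that something is new, unique, unknown or untested is made for them only; others in the source may bear on it.

Measured compounds, all in a functional assay on HeLa cells (Homo sapiens) for antiproliferative activity, read by MTT assay, with a stated time of 48 h; a lower number here means a stronger inhibitor, a higher number a weaker inhibitor:

compound 1 `Cc1cnc(Nc2ccc(S(C)(=O)=O)cc2)nc1Nc1nc2ccc(F)cc2s1`: only a limit, > 50000 nM
compound 2 `COc1ccc2nc(Nc3ccnc(Nc4ccc(S(N)(=O)=O)cc4)n3)sc2c1`: 1730 nM
compound 3 `Cc1cnc(Nc2ccc(S(N)(=O)=O)cc2)nc1Nc1nc2ccc(F)cc2s1`: 3460 nM

Compound 2 and compound 3 share the same kind of change in a different setting; the difference between their two cores is not broken down here. Their two numbers in this assay lie within the usual scatter of each other, so no order between them is claimed.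

Among the compounds with values here, the one measured step is from compound 3 to compound 1: methyl in place of amino on a sulfonyl sulfur. It gives an at least 14-fold higher number from compound 3 to compound 1 (1.15 log units; beyond the scatter), and the value of compound 1 is a limit of the assay (the limit of > 50000 nM in this assay, at which 1 of the 3 values shown sits), so the true size of the step may be larger still.

Compound 4 `COc1ccc2nc(Nc3ccnc(Nc4ccc(S(C)(=O)=O)cc4)n3)sc2c1` is not yet measured. It stands to compound 2 as compound 1 stands to compound 3: methyl in place of amino on a sulfonyl sulfur. The two places are described in the same words, so this is the same change, made on a different core.

For this assay the expectation for compound 4 rests on the step from compound 3 to compound 1, which was an at least 14-fold higher number from compound 3 to compound 1 (1.15 log units; beyond the scatter). A step of about a 17-fold higher number from compound 2 to compound 4 (1.24 log units; beyond the scatter) is therefore expected from compound 2 to compound 4. Starting from the value of compound 2, 1730 nM, compound 4 is estimated at 30000 nM, with a range from 8000 nM to 50000 nM. There is a real chance that for compound 4 only a limit of the assay will be reported.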

Compound 4, half-maximal inhibitory concentration: 4130 nM
The estimate for compound 4 lay 7.3-fold (0.86 log units) above the measured number; measured number below the stated range.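

In this assay, the change from sulfamoyl to methylsulfonyl gives a 2.4-fold higher number from compound 2 to compound 4 (0.38 log units; beyond the scatter), so the higher number seen on the core of compound 3 recurs on the core of compound 2, but the size of the step does not carry over: the same change on two cores in this assay, an at least 14-fold higher number (1.15 log units; beyond the scatter) from compound 3 to compound 1 and a 2.4-fold higher number (0.38 log units; beyond the scatter) from compound 2 to compound 4, at least 6.0-fold (0.78 log units) apart, beyond the scatter of two such steps. Compound 1 gives > 50000 nM, which is a limit of the assay and not a number. With one pair on each core, the series shows that the direction of this change held twice and that its size differed between the cores, but it does not show which feature of the cores goes with that difference, nor whether the direction would hold on a third core.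

The compounds shown leave open how other groups on the sulfonyl sulfur would read, such as a dimethylamino group or a longer chain like ethyl, and how a carboxylic acid in place of the whole sulfamoyl group would compare on either core. They also leave open how the two cores relate step by step, as no pair shown links them through a change in one place.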